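Larger Groups on an Aromatic Nitrogen Raise the Number

The compounds below may be only part of what the source reports. "The series", "measured", "known", "first", "only" and "open" are said of these compounds alone.

Three compounds have been measured in a functional assay on HT-29 cells (Homo sapiens) for inhibition, read by luminescence and CellTiter-Glo, with a stated time of 24 h; on this read-out lower numbers stand for an effect already at smaller amounts and higher numbers for an effect only at larger amounts of compound:

Compound 1 `CN1C(=S)[C@@H](NC(=O)c2nc(Cc3ccccc3)n(C)n2)COc2ccccc21`: 2.5 nM
Compound 2 `CCCCn1nc(C(=O)N[C@H]2COc3ccccc3N(C)C2=S)nc1Cc1ccccc1`: 510 nM
Compound 3 `CN1C(=S)[C@@H](NC(=O)c2nc(Cc3ccccc3)n(C3CCOC3)n2)COc2ccccc21`: 1580 nM

Compound 2 holds the second highest number of the three. Its nearest neighbour is compound 3, reached by a 3.1-fold higher number from compound 2 to compound 3 (0.49 log units; beyond the scatter); its furthest is compound 1, from which it is separated by a 200-fold higher number from compound 1 to compound 2 (2.31 log units; beyond the scatter).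

Compound 4 `CN1C(=S)[C@@H](NC(=O)c2nc(Cc3ccccc3)n(C3CCN(C(=O)OC(C)(C)C)C3)n2)COc2ccccc21` has not yet been measured. It differs from compound 2 in one place: a group of 12 heavy atoms (9 carbon, 1 nitrogen, 2 oxygen; one five-membered non-aromatic ring with 1 hetero atom) in place of a group of 4 heavy atoms (4 carbon; no ring), on an aromatic nitrogen

Going by the values given here, three measured steps bear on this change, and all of them concern the same aromatic nitrogen. Going from methyl to butyl gave a 200-fold higher number from compound 1 to compound 2 (2.31 log units; beyond the scatter), going from methyl to oxolan-3-yl gave a 630-fold higher number from compound 1 to compound 3 (2.80 log units; beyond the scatter), and going from butyl to oxolan-3-yl gave a 3.1-fold higher number from compound 2 to compound 3 (0.49 log units; beyond the scatter). Among these three compounds, each larger group on that nitrogen brought a higher number, and the ring-bearing group of compound 3 gave the highest. The group entering in compound 4 is larger still than either butyl or oxolan-3-yl and also carries a five-membered non-aromatic ring, so a further rise beyond the scatter is expected, at least as large as the modest step to compound 3 and possibly larger.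

Compound 4 is therefore expected to give 3000 nM, within a range from 800 nM to 12000 nM. The expected step is a 5.9-fold higher number from compound 2 to compound 4 (0.77 log units; beyond the scatter).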

Compound 4, half-maximal effective concentration: > 10000 nM
Compound 4 gave a limit, no number; the forecaster's own chance of this, stated with the estimate: 15%; middle value at least 3.3-fold (0.52 log units) away from the limit.
By their numbers in this assay, from the lowest: compound 1; then compound 2; then compound 3. At a limit, above all of these: compound 4.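

In this assay compound 4 gives a limit of the assay and not a number: the limit of > 10000 nM in this assay, at which 1 of the 4 values shown sits. Going by these compounds alone, the step from the oxolan-3-yl group, an at least 6.3-fold higher number from compound 3 to compound 4 (0.80 log units; beyond the scatter), shows that the rise on this aromatic nitrogen goes on when a five-membered non-aromatic ring stays in place and the group around it grows, a comparison that the earlier compounds, with only one ring-bearing group, could not offer. With an at least 19-fold higher number from compound 2 to compound 4 (1.29 log units; beyond the scatter) and an at least 4000-fold higher number from compound 1 to compound 4 (3.60 log units; beyond the scatter), the number climbs with each larger group across all four compounds, and none of them goes against this order, though the top of the range now stands only as a limit.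

The compounds shown cannot separate the size of the group from what it contains, since the group of compound 4 differs from butyl and oxolan-3-yl in several ways at once. As far as these compounds go, how a small chain such as ethyl, a ring carrying a free amine, or a carboxylic acid on the same nitrogen would compare with the methyl of compound 1 remains open.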